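This account rests on a few compounds, and the source may have more. Where it says the series, first, only, none or still open, it means among the compounds named here.

Among the measured compounds shown here, compound 1, `CNc1nc(-n2cc(-c3ccccc3)nn2)nc2c1ncn2[C@@H]1O[C@H](CO)[C@@H](O)[C@H]1O`, is one of three compounds measured in an assay on CHO cells for displacement of a labelled ligand from adenosine receptor A3 (Homo sapiens) (a lower number here means a stronger inhibitor, a higher number a weaker inhibitor), where compound 1 gives 14.9 nM. Two further compounds differ from compound 1 in more than one place: compound 2, `CCNC(=O)[C@H]1O[C@@H](n2cnc3c(NC)nc(-n4cc(Cc5ccccc5)nn4)nc32)[C@H](O)[C@@H]1O`, gives 2.8 nM, and compound 3, `CCNC(=O)[C@H]1O[C@@H](n2cnc3c(NC)nc(-n4ccnn4)nc32)[C@H](O)[C@@H]1O`, gives 2.1 nM. Compound 1 thus stands highest of the three numbers, and both other compounds lie beyond the scatter below it. Between compound 2 and compound 3 the only single change is the removal of a group from the five-membered aromatic ring, and that step, a 1.3-fold lower number from compound 2 to compound 3 (0.12 log units; within the scatter), stays within the scatter.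

Compound 4, `CNc1nc(-n2cc(CC3CCCCC3)nn2)nc2c1ncn2[C@@H]1O[C@H](CO)[C@@H](O)[C@H]1O`, differs from compound 1 by cyclohexylmethyl in place of phenyl on an aromatic carbon. For the measured compounds named here, the one measured step that touches the same aromatic carbon is a 1.3-fold lower number from compound 2 to compound 3 (0.12 log units; within the scatter), and because that step is within the scatter, the group at this position appears to change the number little. The step of a 1.0-fold higher number from compound 1 to compound 4 (0.00 log units; within the scatter) is therefore expected to stay within the scatter. Compound 4 is estimated at 15 nM, in a range from 5 nM to 45 nM.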

Compound 4, inhibition constant: 21.3 nM
The estimate for compound 4 lay 1.4-fold (0.15 log units) below the measured number; the range from low to high includes it.
By their numbers in this assay, from the lowest: compounds 3 and 2 (each within the scatter of the next); then compounds 1 and 4 (each within the scatter of the next).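

Among the compounds shown here, the step of a 1.4-fold higher number from compound 1 to compound 4 (0.16 log units; within the scatter) in this assay is the first at this aromatic carbon on the core of compound 1, and it stays within the scatter. Here, a six-membered ring of carbon only can lose its aromatic character and gain one more carbon in its group without a change beyond the scatter, which extends the earlier finding from the other core, where only benzyl and hydrogen were compared. No measurement at hand offers an explanation for this result.

Every group shown at this carbon contains only carbon and hydrogen, so it remains open whether an amine or a carboxylic acid would also leave the number within the scatter. Also open, going by these compounds, is how plain hydrogen at this carbon would compare on the core of compound 1.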